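Series notes: bromo in place of chloro

This account rests on a few compounds, and the source may have more. Where it says the series, first, only, none or still open, it means among the compounds named here.

In a functional assay on HCT-116 cells (Homo sapiens) for inhibition, read by colorimetric assay, with a stated time of 3 days (on this read-out higher numbers stand for weaker inhibition and lower numbers for stronger inhibition), compound 1 (`O=C(CCCCCCNC(=O)C(O)(O)C(F)(F)F)Nc1cccc2ccccc12`) gives 6480 nM and compound 2 (`CC(=O)c1ccc(NC(=O)CCCCCCNC(=O)C(O)(O)C(F)(F)F)cc1`) gives 12100 nM. Compound 3 (`O=C(CCCCCCNC(=O)C(O)(O)C(F)(F)F)Nc1nc2ccc(Cl)cc2s1`) gives 11000 nM, within the scatter of both other values. Compound 4 (`O=C(CCCCCCNC(=O)C(O)(O)C(F)(F)F)Nc1nc2ccc(Br)cc2s1`) is still unmeasured and differs from compound 3 by one change: bromo in place of chloro on an aromatic carbon. Going by the values given here, no measured pair differs in one place, so the data offer no direct precedent for this step. No shift beyond the scatter is expected in this assay, in either direction. The estimate starts from compound 3 at 11000 nM. The expected step, a 1.1-fold lower number from compound 3 to compound 4 (0.04 log units; within the scatter), stays within the scatter. For compound 4 the estimated value is 10000 nM, with an expected range of 5500 nM to 19000 nM.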

Compound 4, half-maximal inhibitory concentration: 10300 nM
Compound 4: the middle estimate sits 1.0-fold (0.01 log units) below what was measured, within the range that was stated.
By their numbers in this assay, from the lowest: compounds 1, 4, 3 and 2 (each within the scatter of the next).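

The series now has its first single-place step: in this assay bromo in place of chloro on an aromatic carbon gives a 1.1-fold lower number from compound 3 to compound 4 (0.03 log units; within the scatter) and so stays within the scatter. At this position the two halogens are not told apart by this read-out. No available measurement bears on a cause for this result.

Still open, as far as these compounds go, is how other groups at the same carbon would read, such as a methoxy group, an amine or a carboxylic acid. Also open, from the compounds shown here alone, is whether a longer chain in the shared core would shift the value.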